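Alpha-1D binding: moving the methyl on the benzyl ether

The source may report more compounds than this note shows. Statements on the series, on what has been measured and on what is new or still open speak of the compounds shown alone.

Measured so far:
- compound 1, `COc1cccc(OC)c1OCCNCCOc1ccccc1OCc1cccc(Cl)c1`, 0.0501 nM
- compound 2, `COc1cccc(OC)c1OCCNCCOc1ccccc1OCc1ccccc1C`, 0.126 nM

Both compounds were run in an assay on CHO cells for displacement of a labelled ligand from Alpha-1D adrenergic receptor (Homo sapiens); on this read-out higher numbers stand for weaker inhibition and lower numbers for stronger inhibition. Going by the values given here, compound 2 stands at the highest of the two numbers; its nearest neighbour is compound 1, and the only measured step, a 2.5-fold higher number from compound 1 to compound 2 (0.40 log units; beyond the scatter), is a modest one but beyond the scatter.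

Compound 3, `COc1cccc(OC)c1OCCNCCOc1ccccc1OCc1cccc(C)c1`, has not yet been measured. It differs from compound 2 by 3-methylphenyl in place of 2-methylphenyl on a saturated chain carbon bound to an oxygen on an aromatic ring. Among the compounds with values here, no measured pair carries out exactly this change; the step from compound 1 to compound 2 swaps both the substituent and its place on the ring at once, so it bears on the new compound only indirectly. It shows that the 3-substituted pattern of compound 1 gave the lower number of the two. The expectation for compound 3 is therefore a number near that of compound 2 or somewhat lower, a step of a 1.6-fold lower number from compound 2 to compound 3 (0.20 log units; within the scatter), with a spread wide enough to cover no change at all. The estimate for compound 3 in this assay is 0.08 nM, expected between 0.03 nM and 0.2 nM.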

Compound 3, inhibition constant: 0.2 nM
Compound 3: the middle estimate sits 2.5-fold (0.40 log units) below what was measured, and the stated range covers the measured number.
By their numbers in this assay, from the lowest: compound 1; then compounds 2 and 3 (each within the scatter of the next).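

Working from this assay, shifting the methyl from 2-methylbenzyl to 3-methylbenzyl on the oxygen of the aromatic ring gives a 1.6-fold higher number from compound 2 to compound 3 (0.20 log units; within the scatter), so the read-out does not separate these two placements of the methyl, and neither can be ranked above the other. The new compound also takes apart the double change in the earlier step: with the substituent's place held constant, methyl in place of chloro on an aromatic carbon gives a 4.0-fold higher number from compound 1 to compound 3 (0.60 log units; beyond the scatter), so here the identity of the substituent registers where the shift of the methyl does not. Nothing available speaks to the reason for either outcome.

Still open is whether a chloro tolerates a change of place on this ring as the methyl does, as chloro appears in only one place among the compounds shown. Also open, from the compounds shown here alone, is how an unsubstituted benzyl, or a methoxy or nitrile in place of the chloro, would read in this assay, and so whether the gap between chloro and methyl extends to other groups.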